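Extending the anilide of compound 2 with a phenyl ring

The source may report more compounds than this note shows. Statements on the series, on what has been measured and on what is new or still open speak of the compounds shown alone.

Three compounds share a chain carrying a trifluoromethyl dihydroxy amide at one end and an aryl amide at the other. In an assay on isolated protein for inhibition of histone deacetylase 8 (Homo sapiens), read by chemiluminescence, with a stated time of 3 h (on this read-out lower numbers stand for stronger inhibition and higher numbers for weaker inhibition), compound 1 `O=C(CCCCCCNC(=O)C(O)(O)C(F)(F)F)Nc1nc2ccccc2s1` gives 5300 nM, compound 2 `O=C(CCCCCCNC(=O)C(O)(O)C(F)(F)F)Nc1ccc(Br)cc1` gives 11000 nM, and compound 3 `O=C(CCCCCCNC(=O)C(O)(O)C(F)(F)F)Nc1ncc(-c2ccc(Br)cc2)s1` gives 10000 nM. Compound 2 holds the highest number of the three, but its gap to compound 3 is within the scatter, while the step of a 2.1-fold higher number from compound 1 to compound 2 (0.32 log units; beyond the scatter) is beyond it.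

Compound 4 `O=C(CCCCCCNC(=O)C(O)(O)C(F)(F)F)Nc1ccc(-c2ccccc2)cc1` differs from compound 2 in one place: phenyl in place of bromo on an aromatic carbon. Among the compounds with values here, no measured step exchanges bromo for phenyl, so the expectation rests on what the numbers show indirectly. Compound 3, which carries a 4-bromophenyl on a larger aromatic group, gives 10000 nM, close to compound 2 at 11000 nM; growing the aryl end has therefore not shifted the read-out beyond the scatter in this set. The step of a 2.1-fold higher number from compound 1 to compound 2 (0.32 log units; beyond the scatter) shows that the aryl amide does matter, yet the size of that effect is modest.

Compound 4 is therefore expected to land near compound 2, with a step of a 1.4-fold lower number from compound 2 to compound 4 (0.14 log units; within the scatter) expected, and an estimated value of 8000 nM in the range 3500 nM to 18000 nM.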

Compound 4, half-maximal inhibitory concentration: 4100 nM
Beside the measured number, compound 4's estimate is 2.0-fold (0.29 log units) above it; the measured number falls inside the stated range.
By their numbers in this assay, from the lowest: compounds 4, 1, 3 and 2 (each within the scatter of the next, the first and the last beyond it).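

The exchange of bromo for phenyl gives a 2.7-fold lower number from compound 2 to compound 4 (0.43 log units; beyond the scatter) in this assay and is the only measured change shown at this aromatic carbon, para to a large group. It shows that the number responds to what this position carries, although the step is modest. The earlier compounds held no change at this position alone, so they could not show that six heavy atoms and a six-membered aromatic ring of carbon only, entering where one bromine leaves, go with stronger rather than weaker inhibition here, and no supporting measurement accounts for the step.

With only bromo and phenyl at this position, the compounds shown leave open whether the shift follows from the added ring or from the loss of bromo, and how a small methyl or a phenyl ring carrying an amine or a carboxylic acid would read. They also leave open whether the same exchange would give a similar step with a longer chain in the shared core.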